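From Pyridine to Isothiazole on a Shared Core

The source may report more compounds than this note shows. Statements on the series, on what has been measured and on what is new or still open speak of the compounds shown alone.

Compound 1 `c1ccc(-c2ccncc2)c(OCC2=NCCN2)c1` is tested in a functional assay for activation of Alpha-1D adrenergic receptor (Homo sapiens), read by calcium flux; a higher number here means that more compound is needed for the effect, a lower number that less compound is needed. For compound 1 the result is only a limit of the assay, < 100000 nM. Compound 2 `c1ccc(-c2ccsc2)c(OCC2=NCCN2)c1` carries thiophen-3-yl in place of pyridin-4-yl and gives 12.6 nM in this assay. Compound 3 `c1ccc(-c2cc[nH]n2)c(OCC2=NCCN2)c1` gives only a limit, < 100000 nM. Because (the limit of < 100000 nM in this assay, at which 2 of the 3 values shown sit), the steps a step that the limit leaves unreadable from compound 1 to compound 2 and a step that the two limits leave unreadable from compound 1 to compound 3 cannot be sized, and a step that the limit leaves unreadable from compound 2 to compound 3 cannot either. Compound 4 `c1ccc(-c2ccns2)c(OCC2=NCCN2)c1` has not yet been measured; it differs from compound 1 by 1,2-thiazol-5-yl in place of pyridin-4-yl on an aromatic carbon. For the measured compounds named here, the only readable number among the three measured compounds is that of compound 2, and compound 4 shares with compound 2 a five-membered ring holding sulfur, while it shares with compound 3 a five-membered ring with two hetero atoms. Compound 4 is therefore expected to fall somewhere between those two outcomes, with an estimated value of 300 nM and a wide range from 20 nM to 20000 nM. As compound 1 holds only a limit, the expected step that the limit leaves unreadable from compound 1 to compound 4 cannot be measured against a firm number.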

Compound 4, half-maximal effective concentration: 25.1 nM
Compound 4: the middle estimate sits 12-fold (1.08 log units) above what was measured; the measured number falls inside the stated range.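

Compound 4 shows that this aromatic carbon tolerates a ring nitrogen: compound 1 and compound 3 also carry nitrogen in the attached ring and stop at a limit, whereas compound 4 gives a readable number. In this assay, putting 1,2-thiazol-5-yl in place of thiophen-3-yl gives a 2.0-fold higher number from compound 2 to compound 4 (0.30 log units; within the scatter), so the two sulfur-holding five-membered rings cannot be told apart here. Among the four compounds shown, only these two give readable numbers, and no compound goes against that pattern.

On these data alone, the steps to compound 4 from compound 1 and from compound 3 cannot be read, so their sizes stay open: the limit of < 100000 nM in this assay, at which 2 of the 4 values shown sit A furan-3-yl group, with oxygen where thiophen-3-yl holds sulfur, would show whether the pattern follows the sulfur or only the five-membered ring.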